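The compounds below may be only part of what the source reports. "The series", "measured", "known", "first", "only" and "open" are said of these compounds alone.

Compound 2, `Nc1ccccc1NC(=O)/C=C/c1ccc(Cn2cnc3c(NC4CCCCC4)nc(Cl)nc32)cc1`, is examined in a functional assay on NCI-H460 cells (Homo sapiens) for antiproliferative activity, read by CCK-8 assay, with a stated time of 72 h, tested at 2 uM (on this read-out lower numbers stand for a weaker effect and higher numbers for a stronger effect at the one concentration tested), alongside compound 1, `CC(C)n1cnc2c(Nc3cccc(Cl)c3)nc(NCOCc3ccc(C(=O)Nc4ccccc4N)cc3)nc21`. In this assay compound 1 gives 28.9%, while compound 2 gives 8.09%, the lower of the two numbers by a margin that lies beyond the usual scatter of this read-out. Compound 2 therefore stands at the bottom of the measured pair.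

The next compound, compound 3, `Nc1ccccc1NC(=O)/C=C/c1ccc(Cn2cnc3c(NCc4ccccc4)nc(Cl)nc32)cc1`, has not yet been measured in this assay. It differs from compound 2 in one place: benzyl in place of cyclohexyl on a nitrogen on an aromatic ring. Among the compounds with values here, no step between two measured compounds of this kind is available, so the size of the change can only be guessed. Since both groups lack donors and acceptors and carry no charge, compound 3 is expected to stay close to compound 2, with a shift of a number 3.9 percentage points higher from compound 2 to compound 3 (within the scatter) that is not expected to go beyond the scatter. Compound 3 is estimated to give 12% in this assay, within a range of 2% to 30%.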

Compound 3, a percentage reported as inhibition, at one concentration (the size of the read-out at that concentration, not a potency): 4.62%
Beside the measured number, compound 3's estimate is 7.4 percentage points above it, and the stated range covers the measured number.
By their numbers in this assay, from the lowest: compounds 3 and 2 (each within the scatter of the next); then compound 1.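

In this assay, benzyl in place of cyclohexyl on a nitrogen on an aromatic ring comes with a number 3.5 percentage points lower from compound 2 to compound 3 (within the scatter). Within the data shown here, this is the first step that can be read at this position, and it shows that exchanging a six-membered non-aromatic ring of carbon for a six-membered aromatic ring of carbon, with one more heavy atom, leaves the read-out within its scatter at the one concentration tested. Nothing at hand accounts for this outcome, so it stands as an observation only.

As far as these compounds go, whether a primary amine or a carboxylic acid on the benzyl ring, or a longer chain such as phenethyl in place of benzyl, would move the number at this position remains open. The compounds shown also leave open whether this step would stay as small with a different group on the shared core.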